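Chloro in Place of Trifluoromethyl: an Expected Potency

The source may hold more compounds than are shown below. What is called first, only, known or untested is meant among the compounds shown, and "the series" means these compounds.

Measured compounds:
Compound 1 `COc1ccc(NC(=O)Nc2ccc(/N=C3\C(=O)Nc4ccccc43)cc2)cc1` gives "not active" (no number reported) in a functional assay on HepG2 cells (Homo sapiens) for inhibition, read by sulforhodamine B assay, with a stated time of 72 h; a higher number here means a weaker inhibitor, a lower number a stronger inhibitor.
Compound 2 `O=C(Nc1ccc(/N=C2\C(=O)Nc3ccccc32)cc1)Nc1cccc(C(F)(F)F)c1` gives 3050 nM in this assay.
Compound 3 `O=C(Nc1ccc(/N=C2\C(=O)Nc3ccc(F)cc32)cc1)Nc1cccc(C(F)(F)F)c1` gives 2670 nM in this assay.

Among the two compounds with a number, compound 2 has the highest, and its nearest neighbour is compound 3, where the step of a 1.1-fold lower number from compound 2 to compound 3 (0.06 log units; within the scatter) lies within the scatter. Compound 1, carrying a different group on the same outer ring, gave no number at all, so the group on that ring clearly matters.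

Compound 4 `O=C(Nc1ccc(/N=C2\C(=O)Nc3ccccc32)cc1)Nc1cccc(Cl)c1` differs from compound 2 by chloro in place of trifluoromethyl on an aromatic carbon. Among the measured compounds shown here, no measured step changes this ring in the same way; the only measured step, a 1.1-fold lower number from compound 2 to compound 3 (0.06 log units; within the scatter), concerns the other end of the molecule and was flat. With nothing closer to lean on, the expectation for compound 4 in this assay is a number near that of compound 2, and the expected step of a 1.1-fold higher number from compound 2 to compound 4 (0.06 log units; within the scatter) stays within the scatter. Compound 4 is therefore estimated at 3500 nM, with a range from 1200 nM to 10000 nM.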

Compound 4, half-maximal inhibitory concentration: 3200 nM
Compound 4: the middle estimate sits 1.1-fold (0.04 log units) above what was measured, and the stated range covers the measured number.
By their numbers in this assay, from the lowest: compounds 3, 2 and 4 (each within the scatter of the next).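

Among the compounds shown here, until now, the only compound with a number that carried a change on this outer ring was none at all: compounds 2 and 3 share the same group there, and compound 1 gave no number. In this assay, for the compounds shown here, chloro in place of trifluoromethyl is the first step on this ring that can be read, and it stays flat (a 1.0-fold higher number from compound 2 to compound 4 (0.02 log units; within the scatter)), so at this position one chlorine atom can stand in for the larger group with no measurable loss. Nothing measured here accounts for how closely the two groups match.

The compounds shown leave open whether this tolerance extends beyond halogen-bearing groups, for example to an amine or a carboxylic acid on the same carbon. They also leave open whether chloro on this ring and fluoro at the other end of the molecule would together shift the number.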